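This account rests on a few compounds, and the source may have more. Where it says the series, first, only, none or still open, it means among the compounds named here.

Compound 2 `O=C(CCCc1ccccc1)Nc1nc2ccccc2c(=O)s1` holds the lowest of the two numbers measured in an assay on mitochondria (strain Sprague-Dawley) for inhibition of Amine oxidase [flavin-containing] B (Rattus norvegicus), read by fluorescence and Amplex Red, with stated times of 30 min and 45 min; on this read-out higher numbers stand for weaker inhibition and lower numbers for stronger inhibition; compound 2 gives 186 nM. Within the data shown here, compound 3 `O=C(CCCc1ccc(Cl)c(Cl)c1)Nc1nc2ccccc2c(=O)s1` stands nearest, giving 3300 nM in this assay, and the step of an 18-fold higher number from compound 2 to compound 3 (1.25 log units; beyond the scatter) is the single change recorded between them. Compound 1 `O=C(CCCc1ccccc1)Nc1nc2ccc(Cl)cc2c(=O)s1` has no number in this assay, only a limit: compound 1 gives > 10000 nM, a limit of the assay rather than a measured value (the limit of > 10000 nM in this assay, at which 1 of the 3 values shown sits). The step of an at least 53-fold lower number from compound 1 to compound 2 (1.73 log units; beyond the scatter) links compound 1 to compound 2.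

The unmeasured compound 4 `O=C(CCc1ccc(Cl)c(Cl)c1)Nc1nc2ccccc2c(=O)s1` differs from compound 2 by 3,4-dichlorophenyl in place of benzyl on a saturated chain carbon, two bonds along the chain from a carbonyl carbon; the change both replaces phenyl with 3,4-dichlorophenyl and shortens the chain joining that ring to the carbonyl. Of the measured steps, only an 18-fold higher number from compound 2 to compound 3 (1.25 log units; beyond the scatter) bears directly on it, being the step that swaps phenyl for 3,4-dichlorophenyl on the longer chain. Among the measured compounds shown here, no measured pair shows the effect of the shorter chain alone. A higher number, meaning weaker inhibition, is therefore expected for compound 4, with the step of a 16-fold higher number from compound 2 to compound 4 (1.21 log units; beyond the scatter) estimated from the phenyl to 3,4-dichlorophenyl swap, the shorter chain remaining an open uncertainty. Compound 4 is expected to give 3000 nM in this assay, within the range 700 nM to 12000 nM.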

Compound 4, half-maximal inhibitory concentration: > 10000 nM
Compound 4: no number, only a limit; the forecaster's own chance of this, stated with the estimate: 20%; at least 3.3-fold (0.52 log units) between middle value and limit.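

The step of an at least 53-fold higher number from compound 2 to compound 4 (1.73 log units; beyond the scatter) rests on a limit of the assay, so it gives only a minimum size for the combined change of ring and chain. In this assay compound 3 gives 3300 nM, so the 3,4-dichlorophenyl group on the longer chain still leaves a measurable number. With that same group on the shorter chain, compound 4 gives > 10000 nM, which is a limit and not a number, so shortening the chain moves this ring from a measured value to the end of the assay's range, where compound 1 also stands: the limit of > 10000 nM in this assay, at which 2 of the 4 values shown sit.

The compounds shown do not separate the two parts of the change in compound 4, so what the shorter chain does to the unsubstituted phenyl ring of compound 2 remains open. Among these compounds, also open is how a single chloro group or a methoxy group on that phenyl ring, or a chain longer than the one in compound 2, would read in this assay.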